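Moving a Methyl Around One Aromatic Ring

A few compounds are considered here, and "the series" means these few. Any claim that something is new, unique, unknown or untested is made for them only; others in the source may bear on it.

Of the compounds shown here, three sharing one core have been measured in a functional assay on HCT-116 cells (Homo sapiens) for antiproliferative activity, read by CCK-8 assay, with a stated time of 72 h; on this read-out lower numbers stand for stronger inhibition and higher numbers for weaker inhibition. Compound 1 `CC1=NN(c2ccc(C)cc2)C(=O)C12C=CC(=O)C=C2c1ccc(C)cc1` gives 9710 nM. Compound 2 `CC1=NN(c2cccc(Cl)c2)C(=O)C12C=CC(=O)C=C2c1ccc(C)cc1` gives 2400 nM, and compound 3 `CC1=NN(c2ccc(Br)cc2)C(=O)C12C=CC(=O)C=C2c1ccc(C)cc1` gives 10600 nM. Compound 2 therefore stands lowest of the three, with a 4.0-fold lower number from compound 1 to compound 2 (0.61 log units; beyond the scatter) and a 4.4-fold higher number from compound 2 to compound 3 (0.65 log units; beyond the scatter) both beyond the scatter, while a 1.1-fold higher number from compound 1 to compound 3 (0.04 log units; within the scatter) lies within it.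

The unmeasured compound 4 `CC1=NN(c2cccc(Cl)c2)C(=O)C12C=CC(=O)C=C2c1cccc(C)c1` keeps every atom of compound 2 but joins them differently: 3-methylphenyl in place of 4-methylphenyl on a double-bonded ring carbon. For the measured compounds named here, no measured step touches this part of the core; the three measured steps all alter the group on the amide-type nitrogen in a ring, and the one change on an aromatic carbon, bromo in place of methyl in a 1.1-fold higher number from compound 1 to compound 3 (0.04 log units; within the scatter), stayed within the scatter. Going by the values given here, the data thus give no direction for moving a methyl from one position to another on a ring of carbon only, and the only comparable small change showed nothing beyond the scatter.

In this assay compound 4 is therefore expected to sit near compound 2, with an estimated step of a 1.1-fold higher number from compound 2 to compound 4 (0.03 log units; within the scatter). The estimate for compound 4 is 2600 nM, within a range of 900 nM to 7500 nM.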

Compound 4, half-maximal inhibitory concentration: 3740 nM
Compound 4: the middle estimate sits 1.4-fold (0.16 log units) below what was measured; low and high end bracket the measured number.
By their numbers in this assay, from the lowest: compounds 2 and 4 (each within the scatter of the next); then compounds 1 and 3 (each within the scatter of the next).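

In this assay, for the compounds shown here, the step at the double-bonded ring carbon, 3-methylphenyl in place of 4-methylphenyl, gives a 1.6-fold higher number from compound 2 to compound 4 (0.19 log units; within the scatter) and is the first reading at this part of the core. Going by these compounds alone, every earlier step concerned the group on the amide-type nitrogen, so the earlier compounds said nothing about the aromatic ring on this carbon; now one pair shows that shifting its methyl leaves the number within the scatter, with 3-chlorophenyl held on the nitrogen. This is a single pair and sets no rule for the position, and nothing available on these compounds bears on why the shift reads as it does.

It remains open whether the same shift would read alike with the 4-methylphenyl or 4-bromophenyl group on the nitrogen, as the pair shown carries only 3-chlorophenyl there. Also open, on these data alone, is how this ring would respond to a different kind of group in place of the methyl, such as a carboxylic acid or an amine, since both groups seen at this position are methylphenyl groups.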